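Moving the Methyl Around the Benzyl Ring

This account rests on a few compounds, and the source may have more. Where it says the series, first, only, none or still open, it means among the compounds named here.

Measured compounds:
compound 1 `CCOC(CC(=O)O)c1ccc(OCc2ccccc2C)cc1` — 79 nM
compound 2 `CCOC(CC(=O)O)c1ccc(OCc2cccc(C)c2)cc1` — 78 nM

In a functional assay on CHO cells for agonist activity at Free fatty acid receptor 1 (Rattus norvegicus), read by calcium flux (a higher number here means that more compound is needed for the effect, a lower number that less compound is needed), compound 1 gives 79 nM, and compound 2 gives 78 nM. Compound 2 stands with the lowest of the two numbers, yet compound 1 lies within the scatter of it, so neither can be set above the other. For the measured compounds named here, the only step among the measured pair, a 1.0-fold lower number from compound 1 to compound 2 (0.01 log units; within the scatter), shows that moving the methyl from one position of the benzyl ring to another left the read-out unchanged. Compound 3 `CCOC(CC(=O)O)c1ccc(OCc2ccc(C)cc2)cc1` differs from compound 2 in the same manner: 4-methylphenyl in place of 3-methylphenyl on a saturated chain carbon bound to an oxygen on an aromatic ring. Going by the values given here, that single step is the only one bearing on this change, and it was flat, so no step beyond the scatter is expected in this assay, in either direction. Compound 3 is therefore estimated at 80 nM, with a range from 35 nM to 180 nM, which corresponds to an expected step of a 1.0-fold higher number from compound 2 to compound 3 (0.01 log units; within the scatter).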

Compound 3, half-maximal effective concentration: 290 nM
Estimate against measurement, compound 3: 3.6-fold (0.56 log units) below, and the stated range ends below it.
By their numbers in this assay, from the lowest: compounds 2 and 1 (each within the scatter of the next); then compound 3.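

In this assay the position of the methyl on the benzyl ring turns out to matter: 4-methylphenyl in place of 3-methylphenyl gives a 3.7-fold higher number from compound 2 to compound 3 (0.57 log units; beyond the scatter) and 4-methylphenyl in place of 2-methylphenyl gives a 3.7-fold higher number from compound 1 to compound 3 (0.56 log units; beyond the scatter), both modest but beyond the scatter. Compound 1 and compound 2 remain within the scatter of each other and compound 3 alone stands apart, something the flat step between the first two could not reveal. Nothing at hand offers a reason for this difference. As far as these compounds go, whether a methoxy group or a chlorine in place of the methyl would show the same order around the benzyl ring stays open. So does whether an unsubstituted benzyl ring would sit with compound 1 and compound 2 or with compound 3.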